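Cytotoxicity Limits Ahead of a Chloro Analogue's Measurement

A few compounds are considered here, and "the series" means these few. Any claim that something is new, unique, unknown or untested is made for them only; others in the source may bear on it.

Compound 1 `O=S(=O)(Nc1ccc(-c2nc3ccccc3o2)cc1)c1cccc(Cl)c1`: in an ADME assay on HEK293 cells (Homo sapiens) for cytotoxicity, read by resazurin assay, with a stated time of 48 h (on this read-out higher numbers stand for lower toxicity in this test and lower numbers for higher toxicity in this test), compound 1 gives > 100000 nM, a limit of the assay.
Compound 2 `O=S(=O)(Nc1ccc(-c2nc3ccccc3o2)cc1)c1ccccc1O`: in this assay compound 2 gives > 100000 nM, a limit of the assay.
Compound 3 `O=S(=O)(Nc1ccc(-c2nc3ccccc3o2)cc1)c1ccc(O)cc1`: in this assay compound 3 gives > 100000 nM, a limit of the assay.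

Going by the values given here, all three measured compounds sit at the same limit, as the limit of > 100000 nM in this assay, at which 3 of the 3 values shown sit, shows, so compound 3 stands no higher and no lower than its two companions on the numbers so far. The step that the two limits leave unreadable from compound 1 to compound 3 and the step that the two limits leave unreadable from compound 2 to compound 3 are both unreadable for the same reason, and the step that the two limits leave unreadable from compound 1 to compound 2 is no different.

Compound 4 `O=S(=O)(Nc1ccc(-c2nc3ccccc3o2)cc1)c1ccc(Cl)cc1` is the next to be measured in this assay. It differs from compound 3 in one place: chloro in place of hydroxy on an aromatic carbon. Among the compounds with values here, none of the measured steps gives a readable size, so the only guide is that a chloro group on the sulfonyl aryl ring, in compound 1, also reached the limit. An expectation of no step beyond the scatter, a step that the limit leaves unreadable from compound 3 to compound 4, therefore rests on that likeness alone. Compound 4 is expected to give about 150000 nM, within 50000 nM to 400000 nM, most probably reported again only as a limit.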

Compound 4, half-maximal cytotoxic concentration: > 100000 nM
Compound 4: a limit, no number; the forecaster's own chance of this, stated with the estimate: 85%; the middle value lies beyond the limit too.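

In this assay compound 4 gives > 100000 nM, a limit of the assay. No step from compound 1, compound 2 or compound 3 to compound 4 can be read, as all four compounds share one limit: the limit of > 100000 nM in this assay, at which 4 of the 4 values shown sit.

The compounds shown leave open what concentration would be half-maximally cytotoxic for any of them, and whether swapping chloro and hydroxy changes it.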